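Amino-methoxybenzyl styryl sulfones: swapping the benzyl substitution pattern

A few compounds are considered here, and "the series" means these few. Any claim that something is new, unique, unknown or untested is made for them only; others in the source may bear on it.

Compound 1, `COc1ccc(N)cc1CS(=O)(=O)/C=C/c1c(OC)cccc1OC`, gives 25000 nM in a functional assay on DU-145 cells (Homo sapiens) for cytotoxicity, read by trypan blue exclusion, with a stated time of 96 h; on this read-out lower numbers stand for stronger inhibition and higher numbers for weaker inhibition.
Compound 2, `COc1ccc(CS(=O)(=O)/C=C/c2c(OC)cc(OC)cc2OC)c(N)c1`, gives 25 nM in this assay.

Compound 2 holds the lowest number of the two measured; its only comparator, compound 1, lies far above it, well beyond the scatter. Compound 3, `COc1cc(OC)c(/C=C/S(=O)(=O)Cc2cc(N)ccc2OC)c(OC)c1`, is the next entry and differs from compound 2 by 5-amino-2-methoxyphenyl in place of 2-amino-4-methoxyphenyl on a saturated chain carbon bound to a sulfonyl sulfur. Within the data shown here, compound 1 already carries the 5-amino-2-methoxyphenyl group on that same carbon, but it differs from compound 3 elsewhere as well, so no single step isolates this change; the two measured values show only that the arrangement in compound 1 sits high and the one in compound 2 sits low. For compound 3 a step toward a higher number, beyond the scatter yet short of the gap seen to compound 1, is expected, a 12-fold higher number from compound 2 to compound 3 (1.08 log units; beyond the scatter). Compound 3 is accordingly estimated at 300 nM, with a range from 30 nM to 5000 nM.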

Compound 3, half-maximal inhibitory concentration: 7500 nM
The estimate for compound 3 lay 25-fold (1.40 log units) below the measured number, and the stated range ends below it.
By their numbers in this assay, from the lowest: compound 2; then compound 3; then compound 1.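

Moving from 2-amino-4-methoxyphenyl to 5-amino-2-methoxyphenyl on a saturated chain carbon bound to a sulfonyl sulfur leaves the atoms unchanged, yet in this assay it gives a 300-fold higher number from compound 2 to compound 3 (2.48 log units; beyond the scatter), so how the same atoms are joined at this carbon is enough for a large step. With 5-amino-2-methoxyphenyl held in place, methoxy in place of hydrogen on an aromatic carbon gives only a 3.3-fold lower number from compound 1 to compound 3 (0.52 log units; beyond the scatter), a modest step. Among these three compounds, the change of group on the chain carbon therefore outweighs the added methoxy. Nothing available here accounts for either step.

From the compounds shown here alone, the methoxy step is read only alongside 5-amino-2-methoxyphenyl, so its size alongside 2-amino-4-methoxyphenyl remains open. Also open, going by these compounds, is how an acetamide or a hydroxy group would compare with the amino group in either arrangement.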